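This account rests on a few compounds, and the source may have more. Where it says the series, first, only, none or still open, it means among the compounds named here.

Of the compounds shown here, three from one series have been tested in an ADME assay on HEK293 cells (Homo sapiens) for cytotoxicity, read by MTT assay, with a stated time of 48 h; on this read-out lower numbers stand for stronger inhibition and higher numbers for weaker inhibition. Compound 1 `COc1ccc(-c2nc(SCC(=O)c3sc(-c4ccccc4)nc3C)[nH]c(=O)c2C#N)cc1` gives 76200 nM in this assay. Compound 2 `Cc1nc(-c2ccc(Cl)cc2)sc1C(=O)CSc1nc(-c2ccc(Cl)c(Cl)c2)c(C#N)c(=O)[nH]1` gives 46900 nM in this assay, and compound 3 `Cc1nc(-c2ccc(Cl)cc2)sc1C(=O)CSc1nc(N)c(C#N)c(-c2ccc(Cl)cc2)n1` gives 73000 nM in this assay. Compound 2 holds the lowest of the three numbers, yet its gaps to compound 3 and to compound 1 both fall within the scatter of repeated measurements, so the three read as alike on this count.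

Compound 4 `COc1ccc(-c2nc(C)c(C(=O)CSc3nc(-c4ccc(Cl)c(Cl)c4)c(C#N)c(=O)[nH]3)s2)cc1` has not yet been measured. It differs from compound 2 in one place: methoxy in place of chloro on an aromatic carbon. For the measured compounds named here, no pair of measured compounds differs in exactly one place, so no measured step guides this change directly. The measured numbers sit close together although the compounds differ at several positions, which suggests that a single exchange of this kind moves this assay little. Compound 4 is therefore expected to give about 60000 nM, with a likely range from 25000 nM to 150000 nM. The step of a 1.3-fold higher number from compound 2 to compound 4 (0.11 log units; within the scatter) is expected to stay within the scatter, with no clear direction.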

Compound 4, half-maximal inhibitory concentration: 45600 nM
Beside the measured number, compound 4's estimate is 1.3-fold (0.12 log units) above it; measured number inside the range.
By their numbers in this assay, from the lowest: compounds 4, 2, 3 and 1 (each within the scatter of the next).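

For the compounds shown here, replacing chloro with methoxy, which turns a 4-chlorophenyl group into a 4-methoxyphenyl group, gives the first change in one place that can be read in this assay, and the step is a 1.0-fold lower number from compound 2 to compound 4 (0.01 log units; within the scatter). The earlier compounds shown here differed in several places at once, whereas this pair shows that, at this carbon para to a large group, an exchange adding one heavy atom and one hydrogen-bond acceptor leaves the two compounds reading alike. No measurement here speaks to the reason for this likeness.

The compounds shown leave open whether an amine, a carboxylic acid or a longer chain such as butoxy at this same carbon would also read alike. They also leave open whether methoxy would read the same in place of a chloro on the other chlorine-bearing ring of compound 2.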